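Indolylethyl chain on the phenyl-substituted triazole

A few compounds are considered here, and "the series" means these few. Any claim that something is new, unique, unknown or untested is made for them only; others in the source may bear on it.

Compound 1 `COc1ccc(Cn2c(CCc3c[nH]c4ccccc34)nnc2[C@H](NC(=O)c2ccccn2)c2c[nH]c3ccccc23)c(OC)c1` gives 1.8 nM in an in vitro assay on LLC-PK1 cells for displacement of a labelled ligand from growth hormone secretagogue receptor type 1 (Homo sapiens); a lower number here means a stronger inhibitor, a higher number a weaker inhibitor. Compound 2 `CCc1ccc(-n2c(CCc3c[nH]c4ccccc34)nnc2[C@H](NC(=O)c2ccccn2)c2c[nH]c3ccccc23)cc1` gives 49 nM in this assay. Compound 3 `O=C(N[C@H](c1c[nH]c2ccccc12)c1nnc(CCc2ccccc2)n1-c1ccccc1)c1ccccn1` gives 105 nM in this assay.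

Compound 3 stands highest of the three measured numbers; compound 2 lies nearest to it, and compound 1 furthest below. Compound 4 `O=C(N[C@H](c1c[nH]c2ccccc12)c1nnc(CCc2c[nH]c3ccccc23)n1-c1ccccc1)c1ccccn1` differs from compound 3 in one place: 1H-indol-3-yl in place of phenyl on a saturated chain carbon, two bonds along the chain from an aromatic carbon. For the measured compounds named here, no measured step covers this chain change. Going by the values given here, the only measured step, a 27-fold higher number from compound 1 to compound 2 (1.43 log units; beyond the scatter), concerns the group on the aromatic nitrogen, and both of those compounds already carry the indolylethyl chain. Among the compounds with values here, compound 3 is the only compound with the phenethyl chain, and it also carries a plain phenyl on the aromatic nitrogen, so the comparison of compound 2 with compound 3 mixes two changes. Both compounds with the indolylethyl chain give lower numbers than compound 3, which suggests that compound 4 is expected to show a moderate decrease, a 2.3-fold lower number from compound 3 to compound 4 (0.37 log units; beyond the scatter). Compound 4 is therefore estimated at 45 nM, within a range from 15 nM to 130 nM.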

Compound 4, half-maximal inhibitory concentration: 160 nM
Beside the measured number, compound 4's estimate is 3.6-fold (0.55 log units) below it; the measured number lies above the stated range.
By their numbers in this assay, from the lowest: compound 1; then compound 2; then compounds 3 and 4 (each within the scatter of the next).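

With a plain phenyl on the aromatic nitrogen, 1H-indol-3-yl in place of phenyl on the chain gives a 1.5-fold higher number from compound 3 to compound 4 (0.18 log units; within the scatter) in this assay, so this change alone does not separate the two compounds beyond the scatter. With the 2-(1H-indol-3-yl)ethyl chain held constant, the larger steps lie elsewhere: a 3.3-fold higher number from compound 2 to compound 4 (0.51 log units; beyond the scatter) follows hydrogen in place of ethyl on an aromatic carbon, and an 89-fold higher number from compound 1 to compound 4 (1.95 log units; beyond the scatter) follows phenyl in place of 2,4-dimethoxybenzyl on an aromatic nitrogen. No measurement at hand accounts for any of these steps.

The compounds shown leave open whether the chain change would also stay within the scatter with 2,4-dimethoxybenzyl on the aromatic nitrogen. They also leave open how this assay would read a longer chain, or an amine in place of the 1H-indol-3-yl.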